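A few compounds are considered here, and "the series" means these few. Any claim that something is new, unique, unknown or untested is made for them only; others in the source may bear on it.

The series shares one core, `C=C/C=C\[C@H](C)[C@H](OC(N)=O)[C@@H](C)[C@H](O)[C@@H](C)C/C(C)=C\[C@H](C)[C@@H](O)[C@@H](C)/C=C\CCc1cccc(F)c1` being compound 1, and varies the aryl group on a saturated chain carbon, two bonds along the chain from a double-bonded chain carbon. Going by the values given here, in a functional assay on MCF7 cells (Homo sapiens) for cytotoxicity (on this read-out lower numbers stand for stronger inhibition and higher numbers for weaker inhibition), compound 1 gives 500 nM, the lowest of the three numbers measured so far. Compound 2, `C=C/C=C\[C@H](C)[C@H](OC(N)=O)[C@@H](C)[C@H](O)[C@@H](C)C/C(C)=C\[C@H](C)[C@@H](O)[C@@H](C)/C=C\CCc1ccc(C)c(O)c1`, gives 4000 nM in this assay, and compound 3, `C=C/C=C\[C@H](C)[C@H](OC(N)=O)[C@@H](C)[C@H](O)[C@@H](C)C/C(C)=C\[C@H](C)[C@@H](O)[C@@H](C)/C=C\CCc1ccsc1`, gives 4000 nM. The two measured steps away from compound 1 are an 8.0-fold higher number from compound 1 to compound 2 (0.90 log units; beyond the scatter) and an 8.0-fold higher number from compound 1 to compound 3 (0.90 log units; beyond the scatter); between the two replacements themselves there is no change at the digits printed from compound 2 to compound 3 (within the scatter).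

Compound 4, `C=C/C=C\[C@H](C)[C@H](OC(N)=O)[C@@H](C)[C@H](O)[C@@H](C)C/C(C)=C\[C@H](C)[C@@H](O)[C@@H](C)/C=C\CCc1cc(O)cc(O)c1`, is not yet measured. It differs from compound 1 by 3,5-dihydroxyphenyl in place of 3-fluorophenyl on a saturated chain carbon, two bonds along the chain from a double-bonded chain carbon. Both measured departures from the 3-fluorophenyl group, to 3-hydroxy-4-methylphenyl and to thiophen-3-yl, cost the same modest amount, and the 3,5-dihydroxyphenyl group is a further departure of the same kind. Among the compounds with values here, no measured step covers a phenyl carrying two hydroxyls, so the expectation rests on those two replacements alone. A step of the size already seen, away from compound 1, is therefore expected; the estimated step is an 8.0-fold higher number from compound 1 to compound 4 (0.90 log units; beyond the scatter). For compound 4 the expected value in this assay is 4000 nM, with a range from 1500 nM to 15000 nM.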

Compound 4, half-maximal inhibitory concentration: > 1000 nM
Compound 4 ended at the assay's limit (the forecaster's own chance of this, stated with the estimate: 5%); the middle value lies beyond the limit too.
By their numbers in this assay, from the lowest: compound 1; then compounds 2 and 3 (each within the scatter of the next).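

In this assay compound 4 gives > 1000 nM, which is a limit of the assay and not a number: the limit of > 1000 nM in this assay, at which 1 of the 4 values shown sits.

Going by these compounds alone, the only reading of this change is an at least 2.0-fold higher number from compound 1 to compound 4 (0.30 log units; that floor lies within the scatter), so 3,5-dihydroxyphenyl on the saturated chain carbon is bounded by a floor and has no measured step size. The steps from compound 2 and compound 3 to compound 4 cannot be read, which leaves undecided whether a phenyl carrying two hydroxyls matches 3-hydroxy-4-methylphenyl and thiophen-3-yl or departs further from 3-fluorophenyl.

On these data alone, how a plain phenyl, a methoxyphenyl or an aminophenyl would read in this assay remains open, and without these the contribution of the fluorine in compound 1 has no reference point. Also open is whether a shorter or longer chain between the aryl group and the double-bonded chain carbon would move the number, since all the compounds shown keep the 2-arylethyl link.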